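A few compounds are considered here, and "the series" means these few. Any claim that something is new, unique, unknown or untested is made for them only; others in the source may bear on it.

Measured in an ADME assay on L1210/0 cells (Mus musculus) for cytotoxicity, with a stated time of 48 h; a lower number here means a stronger inhibitor, a higher number a weaker inhibitor:
- compound 1 `OC[C@@H]1C[C@H](Cn2cnc3c(Cl)ncnc32)c2c(-c3ccccc3)nnc(-c3ccccc3)c21`: > 200000 nM, a limit of the assay
- compound 2 `CC1(C)[C@@H](Cn2cnc3c(Cl)nc(N)nc32)CC[C@@]1(C)CO`: 50000 nM
- compound 3 `Cc1ccc(S(=O)(=O)/C=C/[C@H]2O[C@@H](n3cnc4c(N)ncnc43)[C@@H](O)[C@H]2O)cc1`: 54000 nM

Compound 1 gives only a limit and not a number. That leaves two numbers, and compound 2 lies within the usual scatter of compound 3.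

Compound 4 `CC1(C)[C@@H](Cn2cnc3c(N)nc(N)nc32)CC[C@@]1(C)CO` carries amino in place of chloro on an aromatic carbon of compound 2: amino in place of chloro on an aromatic carbon. For the measured compounds named here, no measured pair shows this exchange, so the expectation rests on compound 2 at 50000 nM alone. A moderate step toward a weaker number in this assay is expected, though a step within the scatter remains possible. The estimated step runs a 1.8-fold higher number from compound 2 to compound 4 (0.26 log units; within the scatter). For compound 4 the estimated value is 90000 nM, with an expected range of 30000 nM to 200000 nM.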

Compound 4, half-maximal inhibitory concentration: > 200000 nM
Compound 4 gave a limit, no number; the forecaster's own chance of this, stated with the estimate: 30%; middle value at least 2.2-fold (0.34 log units) away from the limit.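

Amino in place of chloro, on the aromatic carbon next to the ring nitrogen, is the first change in a single place that can be read in this assay, and it gives an at least 4.0-fold higher number from compound 2 to compound 4 (0.60 log units; beyond the scatter). At this position, then, the amino group goes with a clearly weaker result than the chloro group. On these data alone, compound 4 gives a limit and not a number, so the full size of the step stays unknown: the limit of > 200000 nM in this assay, at which 2 of the 4 values shown sit.

As far as these compounds go, whether the shift follows from losing chloro or from gaining amino remains open. So does how a bromo, methoxy or methylamino group would read at this position.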